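A few compounds are considered here, and "the series" means these few. Any claim that something is new, unique, unknown or untested is made for them only; others in the source may bear on it.

Measured compounds:
- compound 1 `COc1ccccc1N1CCN(CC(=O)N2CCN(c3nnc(-c4ccccc4)c(-c4ccccc4)n3)CC2)CC1`: 167000 nM
- compound 2 `Cc1ccc(-c2nnc(N3CCN(C(=O)CN4CCN(c5ccccc5)CC4)CC3)nc2-c2ccc(C)cc2)cc1`: 914000 nM

Both were tested in a functional assay on MCF7 cells (Homo sapiens) for cytotoxicity, read by MTT assay, with a stated time of 24 h; on this read-out lower numbers stand for stronger inhibition and higher numbers for weaker inhibition. Of the two numbers, compound 2 has the higher one, and compound 1 gives the lower value, a gap that lies beyond the usual scatter. The unmeasured compound 3 `Cc1ccc(-c2nnc(N3CCN(C(=O)CN4CCN(c5ccc([N+](=O)[O-])cc5)CC4)CC3)nc2-c2ccc(C)cc2)cc1` is compound 2 with one change: nitro in place of hydrogen on an aromatic carbon, on an aromatic carbon of a six-membered aromatic ring of carbon only. Among the compounds with values here, no measured pair shows this exact change, so the size of its effect is unknown. A small step is expected, a 1.5-fold lower number from compound 2 to compound 3 (0.18 log units; within the scatter), within or near the scatter. Compound 3 is therefore estimated at 600000 nM, with a range from 200000 nM to 2000000 nM.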

Compound 3, half-maximal inhibitory concentration: 845000 nM
For compound 3 the middle estimate is 1.4-fold (0.15 log units) below the measured one; measured number inside the range.
By their numbers in this assay, from the lowest: compound 1; then compounds 3 and 2 (each within the scatter of the next).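

In this assay, going from phenyl to 4-nitrophenyl, with nitro in place of hydrogen on an aromatic carbon para to a large group, gives a 1.1-fold lower number from compound 2 to compound 3 (0.03 log units; within the scatter) and so no difference that stands out from the scatter. Within the data shown here, this position therefore accepts a nitro group without a readable effect on the number, which the earlier compounds could not show. No measurement at hand offers an explanation for this result. Still open, going by these compounds, is whether an amine or a carboxylic acid on this same carbon would give a step beyond the scatter. On these data alone, whether nitro behaves the same way on the core of compound 1 also remains unknown.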